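A few compounds are considered here, and "the series" means these few. Any claim that something is new, unique, unknown or untested is made for them only; others in the source may bear on it.

In a functional assay on DU-145 cells (Homo sapiens) for inhibition, read by trypan blue exclusion, with a stated time of 96 h (on this read-out lower numbers stand for stronger inhibition of growth and higher numbers for weaker inhibition of growth), compound 3 (`O=C(/C(=C\c1ccc(O)cc1)SCc1ccc(Cl)cc1)c1ccc(Cl)cc1`) gives 10000 nM. That number is level with compound 2 (`O=C(/C(=C\c1ccc(O)cc1)SCc1ccc(Cl)cc1)c1ccc(Br)cc1`) at 10000 nM, and the two share the lowest number of the three measured compounds. Compound 1 (`Cc1ccsc1/C=C(/SCc1ccc(Cl)c(Cl)c1)C(=O)c1ccc(Cl)cc1`) gives a clearly higher 50000 nM.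

The next structure is compound 4 (`O=C(/C(=C\c1ccc(O)cc1)SCc1ccc(Cl)c(Cl)c1)c1ccc(Cl)cc1`), in which chloro takes the place of hydrogen on an aromatic carbon, so that 4-chlorobenzyl becomes 3,4-dichlorobenzyl: chloro in place of hydrogen on an aromatic carbon. Going by the values given here, only one measured step is available, no change at the digits printed from compound 2 to compound 3 (within the scatter), and it is a halogen exchange at a different place, so it says little about this addition. Compound 1 already carries the 3,4-dichlorobenzyl group, but it differs from compound 3 elsewhere as well, so the number of compound 1, 50000 nM, cannot be credited to that group. Among the compounds with values here, no measured pair isolates this change. In this assay no shift beyond the scatter is therefore expected, and no direction is favoured.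

The expected change is a 1.3-fold lower number from compound 3 to compound 4 (0.10 log units; within the scatter).

For compound 4 the estimate is 8000 nM, with an expected range of 2500 nM to 30000 nM.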

Compound 4, concentration for 50% growth inhibition: 1000 nM
For compound 4 the middle estimate is 8.0-fold (0.90 log units) above the measured one; measured number below the stated range.
By their numbers in this assay, from the lowest: compound 4; then compounds 2 and 3 (each within the scatter of the next); then compound 1.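

In this assay, going by these compounds alone, the change from 4-chlorobenzyl to 3,4-dichlorobenzyl gives a 10-fold lower number from compound 3 to compound 4 (1.00 log units; beyond the scatter) and so shows that this position responds to a single added chloro, whereas the only earlier step, a halogen exchange at a different place, stayed within the scatter. With 3,4-dichlorobenzyl held constant, 4-hydroxyphenyl in place of 3-methylthiophen-2-yl gives a 50-fold lower number from compound 1 to compound 4 (1.70 log units; beyond the scatter) and shows that the high number of compound 1 cannot be read as a property of the 3,4-dichlorobenzyl group alone. The group on the double-bonded chain carbon therefore also weighs heavily on the number.

From the compounds shown here alone, whether fluoro, methoxy or trifluoromethyl at the same place would match the added chloro remains open. So does the effect of an amine or a carboxylic acid in place of the hydroxy group of 4-hydroxyphenyl. Nothing given here explains either step.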